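This account rests on a few compounds, and the source may have more. Where it says the series, first, only, none or still open, it means among the compounds named here.

Measured in an ADME assay on microsomes from liver (Homo sapiens) for metabolic stability, tested at 2.5 uM; on this read-out lower numbers stand for slow clearance and higher numbers for fast clearance:
Compound 1 `O=S(=O)(c1cc(Cl)cc(Cl)c1)c1cnc2c(F)cccc2c1-c1cccc(Cl)c1` gives 1.2 mL/min.
Compound 2 `COc1ccc(-c2c(S(=O)(=O)c3cc(Cl)cc(Cl)c3)cnc3c(F)cccc23)cc1` gives 2.11 mL/min.
Compound 3 `COc1cccc(-c2c(S(=O)(=O)c3cc(Cl)cc(Cl)c3)cnc3c(F)cccc23)c1` gives 2.31 mL/min.

Compound 3 holds the highest of the three numbers, yet neither gap separates it from the others beyond the scatter: a 1.1-fold higher number from compound 2 to compound 3 (0.04 log units; within the scatter) and a 1.9-fold higher number from compound 1 to compound 3 (0.28 log units; within the scatter). The three compounds thus sit in one band, with only a small spread between them.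

Compound 4 `O=S(=O)(c1cc(Cl)cc(Cl)c1)c1cnc2c(F)cccc2c1-c1cccc(F)c1` is not yet measured. Relative to compound 3 it carries fluoro in place of methoxy on an aromatic carbon. The measured step that bears most directly on this is a 1.9-fold higher number from compound 1 to compound 3 (0.28 log units; within the scatter), in which chloro gave way to methoxy on the same aromatic carbon, the reverse sense of the present change; it stayed within the scatter. The step of a 1.8-fold higher number from compound 1 to compound 2 (0.25 log units; within the scatter), also an exchange of a halogen-bearing ring for a methoxy-bearing one, stayed within the scatter as well. Taking the halogen-to-methoxy steps as a guide run backwards, the expected outcome for compound 4 is estimated as a 1.5-fold lower number from compound 3 to compound 4 (0.19 log units; within the scatter). Compound 4 is therefore estimated at 1.5 mL/min, with a range from 0.75 mL/min to 3 mL/min.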

Compound 4, intrinsic clearance in a liver preparation (reported as CLH), per the amount of preparation that the assay uses: 1.08 mL/min
The estimate for compound 4 lay 1.4-fold (0.14 log units) above the measured number, and the stated range covers the measured number.
By their numbers in this assay, from the lowest: compounds 4, 1, 2 and 3 (each within the scatter of the next, the first and the last beyond it).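

In this assay, among the compounds shown here, the change from 3-methoxyphenyl to 3-fluorophenyl gives (a 2.1-fold lower number from compound 3 to compound 4 (0.33 log units; beyond the scatter)), the only step so far at this position to pass the scatter, and it does so only modestly. The halogen exchange at the same aromatic carbon, (a 1.1-fold lower number from compound 1 to compound 4 (0.05 log units; within the scatter)), does not separate fluoro from chloro, and (a 2.0-fold lower number from compound 2 to compound 4 (0.29 log units; within the scatter)) does not separate 3-fluorophenyl from 4-methoxyphenyl, so compound 2 goes against any general reading of methoxy-bearing rings as set apart from halogen-bearing ones, and the separation rests on the pair compound 3 and compound 4 alone. No measurement at hand accounts for the step from methoxy to fluoro.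

The compounds shown leave open whether a group of another kind on this ring, such as an amine, a carboxylic acid or a longer ether chain, would carry the number out of this narrow band. As far as these compounds go, whether the methoxy-to-fluoro step reads the same with a different group elsewhere on the core of compound 1 also stays open.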